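The source may report more compounds than this note shows. Statements on the series, on what has been measured and on what is new or still open speak of the compounds shown alone.

Compound 1 `CCCc1c(OCCCOc2ccc(C(=O)N(C)C)c(OC)c2CCC)ccc2c1OC(C(=O)O)CC2`: 0.15 nM
Compound 2 `CCCc1c(OCCCOc2ccc(C(=O)NC(C)C)c(OC)c2CCC)ccc2c1OC(C(=O)O)CC2`: 0.1 nM

In an assay on isolated protein for inhibition of leukotriene B4 receptor 1 (Homo sapiens) (a higher number here means a weaker inhibitor, a lower number a stronger inhibitor), compound 2 gives the lower of the two numbers, with compound 1 nearest; the step of a 1.5-fold lower number from compound 1 to compound 2 (0.18 log units; within the scatter) lies within the scatter, so the two stand level. Compound 3 `CCCc1c(OCCCOc2ccc(C(N)=O)c(OC)c2CCC)ccc2c1OC(C(=O)O)CC2` has not yet been measured. The change from compound 2 to compound 3 is hydrogen in place of isopropyl on an amide-type nitrogen. Among the measured compounds shown here, one measured step bears on it: the exchange on the same amide-type nitrogen, where a 1.5-fold lower number from compound 1 to compound 2 (0.18 log units; within the scatter) shows that replacing one alkyl group by another left the number within the scatter. For the measured compounds named here, removing the alkyl group entirely goes further than anything measured, and no compound with a bare carbamoyl is on record, so the expectation rests only on that indifference. Compound 3 is therefore expected to show, if anything, a small step toward a higher number, a 2.0-fold higher number from compound 2 to compound 3 (0.30 log units; within the scatter). In this assay compound 3 is estimated at 0.2 nM, with a range from 0.05 nM to 0.8 nM.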

Compound 3, half-maximal inhibitory concentration: 2.4 nM
Compound 3: the middle estimate sits 12-fold (1.08 log units) below what was measured; the whole stated range lies below it.
By their numbers in this assay, from the lowest: compounds 2 and 1 (each within the scatter of the next); then compound 3.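

In this assay, hydrogen in place of isopropyl on the amide-type nitrogen gives a 24-fold higher number from compound 2 to compound 3 (1.38 log units; beyond the scatter), and amino in place of dimethylamino on the carbonyl carbon gives a 16-fold higher number from compound 1 to compound 3 (1.20 log units; beyond the scatter). The earlier exchange, a 1.5-fold lower number from compound 1 to compound 2 (0.18 log units; within the scatter), lay within the scatter, so the indifference it showed holds only between these two alkylated amides and does not extend to the bare carbamoyl: among the three compounds, the low numbers belong to those with alkyl on this nitrogen. Nothing shown explains why removing the alkyl group matters so much. On these data alone, it remains open whether a single methyl or ethyl on this nitrogen would be enough to keep the number low, and whether a longer chain such as n-butyl would do the same. Also open, as far as these compounds go, is how a carboxylic acid in place of the amide would behave.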